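Ester replacement on the shared core: toward compound 3

The compounds below may be only part of what the source reports. "The series", "measured", "known", "first", "only" and "open" are said of these compounds alone.

Compound 2 `O=COC1(C(=O)Nc2ccc([N+](=O)[O-])cc2)CCCCC1` carries a formate ester on the shared core. Among the measured compounds shown here, in a functional assay on MCF7 cells (Homo sapiens) for inhibition, read by MTT assay, with a stated time of 72 h (on this read-out higher numbers stand for weaker inhibition and lower numbers for stronger inhibition), compound 2 gives 35.4 nM, the higher of the two numbers so far. For the measured compounds named here, its only neighbour is compound 1 `O=C(OC1(C(=O)Nc2ccc([N+](=O)[O-])cc2)CCCCC1)c1ccc(Cl)cc1`, which in this assay gives 15 nM. Going by the values given here, the single measured step, a 2.4-fold higher number from compound 1 to compound 2 (0.37 log units; beyond the scatter), shows that hydrogen in place of 4-chlorophenyl on the carbonyl carbon moves the number upward beyond the scatter.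

Compound 3 `CC(=O)Oc1ccccc1C(=O)OC1(C(=O)Nc2ccc([N+](=O)[O-])cc2)CCCCC1` is not yet measured. It differs from compound 2 by 2-acetoxyphenyl in place of hydrogen on a carbonyl carbon. This runs in the reverse sense of the measured step: an aromatic group re-enters on the carbonyl carbon, though as 2-acetoxyphenyl rather than 4-chlorophenyl, so the measured step bears on it only by analogy. A modest drop in the number in this assay is therefore expected, roughly the size seen before. The expected step is a 2.0-fold lower number from compound 2 to compound 3 (0.29 log units; within the scatter). Compound 3 is estimated at 18 nM in this assay, with a range of 8 nM to 45 nM.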

Compound 3, half-maximal inhibitory concentration: 16.9 nM
For compound 3 the middle estimate is 1.1-fold (0.03 log units) above the measured one, within the range that was stated.
By their numbers in this assay, from the lowest: compounds 1 and 3 (each within the scatter of the next); then compound 2.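

Placing an aromatic group on the carbonyl carbon now lowers the number in this assay with a second, differently substituted ring: 2-acetoxyphenyl in place of hydrogen gives a change beyond the scatter (a 2.1-fold lower number from compound 2 to compound 3 (0.32 log units; beyond the scatter)). Exchanging 4-chlorophenyl for 2-acetoxyphenyl gives no readable difference (a 1.1-fold higher number from compound 1 to compound 3 (0.05 log units; within the scatter)), so this position accepts both substituted phenyl groups shown with values within the scatter of each other. No supporting data are available to explain either step.

Going by these compounds, whether the position needs an aromatic ring at all remains open, since the comparison so far covers only hydrogen and these two phenyl groups; a methyl group or a longer alkyl chain on the carbonyl carbon would address this. Also open, on these data alone, is whether the ester link itself matters, which an amide in its place would test.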